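Nitro Addition on a Furan Ring in a Paw Edema Test

This account rests on a few compounds, and the source may have more. Where it says the series, first, only, none or still open, it means among the compounds named here.

Compound 1 `COc1ccc(Cl)c(-c2nnc3n2NC(c2ccco2)S3)c1` and compound 3 `COc1ccc(Cl)c(-c2nnc3n2NC(c2ccc([N+](=O)[O-])o2)S3)c1` share the same core, and compound 3 carries nitro in place of hydrogen on an aromatic carbon. In a functional assay on the whole organism (strain Wistar Albino) for inhibition, with Rattus norvegicus as the target, read by paw edema, with a stated time of 3 h, at a dose of 20 mg/kg (on this read-out lower numbers stand for less inhibition and higher numbers for more inhibition at the one dose given (going by the name of the read-out)), compound 1 gives 23.1%, and compound 3 gives 21.7%; the step of a number 1.4 percentage points lower from compound 1 to compound 3 (within the scatter). Compound 2 `COc1ccc(Cc2nnc3n2NC(c2ccco2)S3)cc1OC` is built on a different core, and the difference between the two cores is not broken down here. In this assay compound 2 gives 21.1%. Compound 4 `COc1ccc(Cc2nnc3n2NC(c2ccc([N+](=O)[O-])o2)S3)cc1OC` has not yet been measured; it differs from compound 2 by nitro in place of hydrogen on an aromatic carbon, the same change at the same place as from compound 1 to compound 3. Because the step of a number 1.4 percentage points lower from compound 1 to compound 3 (within the scatter) stayed within the scatter, the step of a number 1.1 percentage points lower from compound 2 to compound 4 (within the scatter) is expected to be small as well. Compound 4 is therefore estimated at 20%, with a range from 13% to 28%.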

Compound 4, a percentage reported as inhibition, in the whole organism at one dose (the size of the read-out at that dose, not a potency): 21.4%
For compound 4 the middle estimate is 1.4 percentage points below the measured one; low and high end bracket the measured number.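

In this assay, putting 5-nitrofuran-2-yl in place of furan-2-yl gives a number 0.3 percentage points higher from compound 2 to compound 4 (within the scatter) on this second core. Neither this step nor the earlier one stands out from the usual scatter, so the nitro group shows no clear gain or loss of inhibition on either core. The change reads alike on the two cores, which shows only that it made no visible difference here at a single dose, not that it would read the same on other cores or at other doses: the same change on two cores in this assay, a number 1.4 percentage points lower (within the scatter) from compound 1 to compound 3 and a number 0.3 percentage points higher (within the scatter) from compound 2 to compound 4, 1.7 percentage points apart, within the scatter of two such steps

The compounds shown leave open whether a different group at the same place on the furan, such as an amine, a carboxylic acid or a longer chain, would move the number beyond the scatter. They also leave open how the nitro change would read on any core other than these two.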